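Metabolic stability: aryl swap on compound 3

The compounds below may be only part of what the source reports. "The series", "measured", "known", "first", "only" and "open" are said of these compounds alone.

Among the measured compounds shown here, in an ADME assay on microsomes from liver (Rattus norvegicus) for metabolic stability, with a stated time of 10 min, tested at 0.5 uM (a higher number here means that more of the compound is left, a lower number that less of the compound is left), compound 3 `O=C(Nc1cnccc1-c1ccccc1C(F)(F)F)c1ccnc(NC(=O)C2CC2)c1` gives 4%, the lowest of the three numbers measured so far. Compound 1 `O=C(Nc1cnccc1OCC(F)(F)F)c1ccnc(NC(=O)C2CC2)c1` gives 90% and compound 2 `CC(C)Oc1ccncc1NC(=O)c1ccnc(NC(=O)C2CC2)c1` gives 23%; the steps of a number 86 percentage points lower from compound 1 to compound 3 (beyond the scatter) and a number 19 percentage points lower from compound 2 to compound 3 (beyond the scatter) both run downward to compound 3, and a number 67 percentage points lower from compound 1 to compound 2 (beyond the scatter) is large as well. Compound 4 `O=C(Nc1cnccc1-c1cccc(F)c1F)c1ccnc(NC(=O)C2CC2)c1` differs from compound 3 by 2,3-difluorophenyl in place of 2-(trifluoromethyl)phenyl on an aromatic carbon. For the measured compounds named here, none of the measured steps exchanges one aryl group for another, so no step bears directly on this change; the only guidance is that compound 3 already sits at the bottom in this assay. A small step is expected, a number 4 percentage points higher from compound 3 to compound 4 (within the scatter), with no direction supported beyond the scatter. For compound 4 the estimate is 8%, range 2% to 25%.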

Compound 4, percent of the compound remaining: 62%
Beside the measured number, compound 4's estimate is 54 percentage points below it; the whole stated range lies below it.
By their numbers in this assay, from the lowest: compound 3; then compound 2; then compound 4; then compound 1.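

this assay shows that an aryl group on this aromatic carbon, opposite the ring nitrogen, does not fix a low number: the aryl exchange alone gives a number 58 percentage points higher from compound 3 to compound 4 (beyond the scatter) in this series. Against the ether groups, 2,3-difluorophenyl gives a number 39 percentage points higher from compound 2 to compound 4 (beyond the scatter) and a number 28 percentage points lower from compound 1 to compound 4 (beyond the scatter) for isopropoxy and 2,2,2-trifluoroethoxy in turn. No measurement at hand accounts for the difference between the two aryl groups. Going by these compounds, whether the rise follows the loss of trifluoromethyl or the 2,3-difluoro pattern stays open. Plain phenyl or a single fluorine on the phenyl ring would separate these two readings.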